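This account rests on a few compounds, and the source may have more. Where it says the series, first, only, none or still open, it means among the compounds named here.

In a functional assay on A549 cells (Homo sapiens) for antiproliferative activity, read by MTT assay, with a stated time of 72 h (on this read-out lower numbers stand for stronger inhibition and higher numbers for weaker inhibition), compound 2 (`CC(C)/C=C/C(=O)Nc1cccc(Oc2nc(Nc3ccn(C)n3)nc3c2CSCC3)c1`) gives 33500 nM, the higher of the two numbers available, while compound 1 (`CCC/C=C/C(=O)Nc1cccc(Oc2nc(Nc3ccn(C)n3)nc3c2CSCC3)c1`) gives 8190 nM. Compound 3 (`C=C(C)C(=O)Nc1cccc(Oc2nc(Nc3ccn(C)n3)nc3c2CSCC3)c1`) has not yet been measured. From compound 2 to compound 3 the change is 1-methylethenyl in place of 3-methylbut-1-en-1-yl on a carbonyl carbon, with 1-methylethenyl in place of 3-methylbut-1-en-1-yl on a carbonyl carbon whose other neighbour is an amide-type nitrogen. Among the measured compounds shown here, only one measured step bears on this change: a 4.1-fold higher number from compound 1 to compound 2 (0.61 log units; beyond the scatter). That step is modest but beyond the scatter, and it is not the same replacement, so the support is thin. For the measured compounds named here, with compound 2 at 33500 nM and that step as the only guide, a modest move to a lower number is expected in this assay. The expected step is a 2.4-fold lower number from compound 2 to compound 3 (0.38 log units; beyond the scatter). For compound 3 the estimate is 14000 nM, with an expected range of 4000 nM to 45000 nM.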

Compound 3, half-maximal inhibitory concentration: 46900 nM
For compound 3 the middle estimate is 3.4-fold (0.53 log units) below the measured one; measured number outside the range, above it.
By their numbers in this assay, from the lowest: compound 1; then compounds 2 and 3 (each within the scatter of the next).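

In this assay the replacement of 3-methylbut-1-en-1-yl by 1-methylethenyl on the carbonyl carbon gives a 1.4-fold higher number from compound 2 to compound 3 (0.15 log units; within the scatter) and so separates these two groups no further, although 5 heavy atoms leave and 3 enter. The replacement of pent-1-en-1-yl by 1-methylethenyl at the same place gives a 5.7-fold higher number from compound 1 to compound 3 (0.76 log units; beyond the scatter) and leaves compound 1 as the only one of the three apart from the others, with the two branched groups level in this assay. No measurement offered here accounts for these steps and the reading stays descriptive.

Open, on these data alone, is whether the unbranched ethenyl group on this carbonyl carbon would read with compound 1 or with compound 3. Also open, as far as these compounds go, is how a longer chain such as hept-1-en-1-yl, or a dimethylamino group at the end of the chain, would read in this assay against compound 1.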